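Trading Nitro for Trifluoromethyl in a Level Series

This account rests on a few compounds, and the source may have more. Where it says the series, first, only, none or still open, it means among the compounds named here.

In an ADME assay for permeability, using PAMPA, with a stated time of 3 h (a lower number here means that the compound crosses the layer more slowly, a higher number that the compound crosses the layer faster), compound 1 (`O=C(Nc1cccc([N+](=O)[O-])c1)c1cc(Cl)ccc1O`) gives 19.5 10^-6 cm/s while compound 2 (`O=C(Nc1ccc([N+](=O)[O-])c(Cl)c1)c1cc(Cl)ccc1O`) gives 12.3 10^-6 cm/s and compound 3 (`O=C(Nc1ccc(F)cc1)c1cc(Cl)ccc1O`) gives 18.2 10^-6 cm/s on the same scale. These numbers sit within the usual scatter of one another, so compound 1 stands level with both. Compound 4 (`O=C(Nc1cccc(C(F)(F)F)c1)c1cc(Cl)ccc1O`) keeps the core of compound 1 and makes one change: trifluoromethyl in place of nitro on an aromatic carbon. Going by the values given here, no measured pair differs in just one place, so the data offer no direct guide to this swap. Compound 3 carries neither group and still gives 18.2 10^-6 cm/s within the scatter of compound 1, so no step beyond the scatter is expected in this assay for this change. The estimated change is a 1.0-fold higher number from compound 1 to compound 4 (0.01 log units; within the scatter) and it is expected to stay inside the scatter. For compound 4 the estimated value is 20 10^-6 cm/s with an expected range from 10 10^-6 cm/s to 38 10^-6 cm/s in this measurement.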

Compound 4, apparent permeability: 4.2 10^-6 cm/s
Compound 4: the middle estimate sits 4.8-fold (0.68 log units) above what was measured; the whole stated range lies above it.
By their numbers in this assay, from the lowest: compound 4; then compounds 2, 3 and 1 (each within the scatter of the next).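

Trifluoromethyl in place of nitro, on an aromatic carbon meta to a large group, gives a 4.6-fold lower number from compound 1 to compound 4 (0.67 log units; beyond the scatter) in this assay and so shows that the number depends on which group sits at this place, something compound 1, compound 2 and compound 3 could not reveal. The exchange removes a group counted with 2 hydrogen-bond acceptors and brings in one counted with 0, but this is a difference between the structures and not an explanation. Nothing measured here accounts for the step.

Still open, as far as these compounds go, is whether other groups at this place, such as a nitrile, an amine or a carboxylic acid, would stay with nitro or with trifluoromethyl. Also open, from the compounds shown here alone, is whether the same exchange would give a similar step on compound 2.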